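The source may report more compounds than this note shows. Statements on the series, on what has been measured and on what is new or still open speak of the compounds shown alone.

Among the measured compounds shown here, compound 1 `CC(C)[C@@H](NC(=O)c1cccc(F)c1)C(=O)N1CCC(c2ccc(Cl)cc2)CC1` is the stronger of the two compounds measured so far in an assay on THP-1 cells for displacement of a labelled ligand from C-C chemokine receptor type 1 (Homo sapiens); a lower number here means a stronger inhibitor, a higher number a weaker inhibitor: compound 1 gives 24 nM. Compound 2 `CC[C@@H](NC(=O)c1ccccc1)C(=O)N1CCC(c2ccc(Cl)cc2)CC1` gives 121 nM in this assay, a number beyond the scatter from that of compound 1; since the two differ in more than one place, nothing further is read from this pair. Compound 3 `CC(C)[C@@H](NC(=O)c1nc2ccccc2s1)C(=O)N1CCC(c2ccc(Cl)cc2)CC1` carries a single change from compound 1: 1,3-benzothiazol-2-yl in place of 3-fluorophenyl on a carbonyl carbon. For the measured compounds named here, no measured pair shows this change, so only a small step is expected in this assay, if anything toward a weaker result, a 1.7-fold higher number from compound 1 to compound 3 (0.22 log units; within the scatter). Compound 3 is therefore estimated at about 40 nM, within 10 nM to 160 nM.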

Compound 3, half-maximal inhibitory concentration: 18 nM
Compound 3: middle estimate off by 2.2-fold (0.35 log units), on the high side; the range from low to high includes it.
By their numbers in this assay, from the lowest: compounds 3 and 1 (each within the scatter of the next); then compound 2.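

At this place on the carbonyl carbon, 1,3-benzothiazol-2-yl can replace 3-fluorophenyl in this assay with a 1.3-fold lower number from compound 1 to compound 3 (0.12 log units; within the scatter) as the step. The position therefore accepts a group with two aromatic rings, more heavy atoms and hydrogen-bond acceptors absent from 3-fluorophenyl, and the two numbers remain within the scatter. Nothing measured here explains this result. Still open, on these data alone, is whether the same place accepts an amine, a carboxylic acid or a longer chain, which would show how far this tolerance extends.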